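Swapping an Aminophenyl Amide for a Pyridyl Amide

A few compounds are considered here, and "the series" means these few. Any claim that something is new, unique, unknown or untested is made for them only; others in the source may bear on it.

Three amides built on one shared core have been tested in a functional assay on HepG2 cells (Homo sapiens) for antiproliferative activity, read by MTT assay, with a stated time of 48 h; on this read-out higher numbers stand for an effect only at larger amounts of compound and lower numbers for an effect already at smaller amounts. Compound 1 `O=C(Nc1nnc(-c2ccc3c(c2)OCCO3)s1)c1ccccc1` carries a plain phenyl on the carbonyl carbon, and in this assay compound 1 gives 34.8 ug/mL. Compound 3 `O=C(Nc1nnc(-c2ccc3c(c2)OCCO3)s1)c1ccc(Cl)nc1` carries 6-chloropyridin-3-yl in that place, and compound 3 gives 15.4 ug/mL; between them a 2.3-fold lower number from compound 1 to compound 3 (0.35 log units; beyond the scatter). Compound 2 `Nc1ccc(C(=O)Nc2nnc(-c3ccc4c(c3)OCCO4)s2)cc1` carries 4-aminophenyl. For compound 2 this assay reports only a limit, > 100 ug/mL, so its true number is not known (the limit of > 100 ug/mL in this assay, at which 1 of the 3 values shown sits). Against the two numbered compounds this places compound 2 at the weaker end: an at least 2.8-fold higher number from compound 1 to compound 2 (0.45 log units; beyond the scatter), and an at least 6.4-fold lower number from compound 2 to compound 3 (0.81 log units; beyond the scatter).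

Compound 4 `O=C(Nc1nnc(-c2ccc3c(c2)OCCO3)s1)c1ccccn1` has not yet been measured. It differs from compound 2 in one place: pyridin-2-yl in place of 4-aminophenyl on a carbonyl carbon. The amino-bearing ring leaves and a ring with one nitrogen enters, a change of the same kind as the one that gave an at least 6.4-fold lower number from compound 2 to compound 3 (0.81 log units; beyond the scatter). Both measured replacements on the carbonyl carbon pointed the same way, toward lower numbers, so a drop beyond the scatter is expected here too. Pyridin-2-yl lacks the chlorine of compound 3, so compound 4 is expected to land nearer compound 1 than compound 3. The expected step is an at least 3.3-fold lower number from compound 2 to compound 4 (0.52 log units; beyond the scatter). Compound 4 is thus estimated at 30 ug/mL, within a range from 10 ug/mL to 90 ug/mL.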

Compound 4, half-maximal effective concentration: > 100 ug/mL
Compound 4: only a limit was reported; the forecaster's own chance of this, stated with the estimate: 20%; at least 3.3-fold (0.52 log units) between middle value and limit.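

In this assay, compound 4 stays at a limit rather than a number, which puts it level with the one other compound reported this way: the limit of > 100 ug/mL in this assay, at which 2 of the 4 values shown sit.

Putting pyridin-2-yl in place of phenyl on the carbonyl carbon gives an at least 2.8-fold higher number from compound 1 to compound 4 (0.45 log units; beyond the scatter), so a ring with one nitrogen does not by itself carry the lower number, and putting pyridin-2-yl in place of 6-chloropyridin-3-yl gives an at least 6.4-fold higher number from compound 3 to compound 4 (0.81 log units; beyond the scatter). Among the four amides, then, only 6-chloropyridin-3-yl gives a lower number than plain phenyl, while 4-aminophenyl and pyridin-2-yl both go the other way, so this position does not simply accept any replacement of the phenyl ring.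

Going by these compounds, with a limit on each side, the step between compound 2 and compound 4 cannot be read, and how far apart these two really lie stays unknown. The compounds shown also leave open whether the chlorine or the pyridine ring matters more in compound 3, a question that a plain pyridin-3-yl or a 4-chlorophenyl group on the same carbonyl carbon could help to separate.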